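Extending methoxy to ethoxy: the step to compound 3

A few compounds are considered here, and "the series" means these few. Any claim that something is new, unique, unknown or untested is made for them only; others in the source may bear on it.

Two compounds share one core and differ at a single aromatic carbon. Compound 1 `C=CCOc1c(C)c(C)c2c(c1C)CCC(C)(COc1ccc(/C=C3\SC(=O)NC3=O)cc1)O2` carries a hydrogen there, while compound 2 `C=CCOc1c(C)c(C)c2c(c1C)CCC(C)(COc1ccc(/C=C3\SC(=O)NC3=O)cc1OC)O2` carries a methoxy. In a functional assay on MCF7 cells (Homo sapiens), tested at 7.5 uM (on this read-out higher numbers stand for a weaker effect at the one concentration tested and lower numbers for a stronger effect), compound 1 gives 2% and compound 2 gives 1%. Of the two numbers shown, compound 2 holds the lower, but the step between them, a number 1 percentage points lower from compound 1 to compound 2 (within the scatter), is within the scatter, so the two cannot be told apart.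

Compound 3 `C=CCOc1c(C)c(C)c2c(c1C)CCC(C)(COc1ccc(/C=C3\SC(=O)NC3=O)cc1OCC)O2` extends the substituent further: methyl in place of hydrogen on a saturated chain carbon bound to an oxygen on an aromatic ring. Going by the values given here, the only measured step that bears on this position is a number 1 percentage points lower from compound 1 to compound 2 (within the scatter), which added an entire methoxy without moving the read-out beyond the scatter; no measured step of methoxy to ethoxy exists here. With both measured values already close to zero in this assay, the step is expected to be small, a number 2 percentage points higher from compound 2 to compound 3 (within the scatter), in no direction beyond the scatter. Compound 3 is therefore estimated at 3% in this assay, with a range from -6% to 14%.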

Compound 3, a percentage reported as activity, at one concentration (the size of the read-out at that concentration, not a potency): 75%
Compound 3: middle estimate off by 72 percentage points, on the low side, outside the stated range (above it).
By their numbers in this assay, from the lowest: compounds 2 and 1 (each within the scatter of the next); then compound 3.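

Read in this assay, the position is not indifferent to what it carries: one added methyl on the saturated chain carbon gives a number 74 percentage points higher from compound 2 to compound 3 (beyond the scatter) and marks a sharp break, and ethoxy measured against hydrogen gives a number 73 percentage points higher from compound 1 to compound 3 (beyond the scatter) in the same direction. Hydrogen and methoxy had looked interchangeable, with a number 1 percentage points lower from compound 1 to compound 2 (within the scatter) inside the scatter, so the earlier pair gave no sign that this position could matter; the effect at the one concentration tested stays strong with those two groups and is largely lost with ethoxy, and this change of methoxy to ethoxy is by far the largest step among the three compounds. Nothing available here accounts for why so small a change has so large a result.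

The compounds shown leave open whether the weakening goes on or levels off with a longer chain such as propoxy, and whether a branched isopropoxy or a hydroxyethoxy group would behave like ethoxy or like methoxy. With a single concentration as the only read-out, they also leave open how far the potency of compound 3 lies from that of compound 2 .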